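Swapping fluoro for nitro: an expectation built on two limits

This account rests on a few compounds, and the source may have more. Where it says the series, first, only, none or still open, it means among the compounds named here.

Compound 1 `O=[N+]([O-])c1ccc2[nH]c(-c3nc(-c4ccccc4)no3)cc2c1` gives > 50000 nM in a functional assay on MCF7 cells (Homo sapiens) for antiproliferative activity, read by WST assay, with a stated time of 72 h; a lower number here means a stronger inhibitor, a higher number a weaker inhibitor; this is a limit, not a number.
Compound 2 `Fc1ccc2[nH]c(-c3nc(-c4ccc(Cl)cc4)no3)cc2c1` gives > 50000 nM in this assay; this too is a limit.

Compound 2 thus stands at the edge of what this assay can report, with no measurable potency shown. Within the data shown here, both values rest at the limit of > 50000 nM in this assay, at which 2 of the 2 values shown sit, so no step between measured compounds can be sized. Compound 3 `O=[N+]([O-])c1ccc2[nH]c(-c3nc(-c4ccc(Cl)cc4)no3)cc2c1` arises from compound 2 by nitro in place of fluoro on an aromatic carbon. Compound 1 carries that same nitro group and likewise reaches only a limit. The expected step is a step that the limit leaves unreadable from compound 2 to compound 3, nothing beyond the scatter. For compound 3 the estimated value is 60000 nM, within 20000 nM to 200000 nM, most likely again reported only as a limit.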

Compound 3, half-maximal inhibitory concentration: > 50000 nM
Compound 3: only a limit was reported; the forecaster's own chance of this, stated with the estimate: 80%; the middle value is on the limit's open side.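

Compound 3 also ends at a limit, so neither its step from compound 2 nor its step from compound 1 can be read: the limit of > 50000 nM in this assay, at which 3 of the 3 values shown sit.

On these data alone, whether nitro, fluoro or chloro changes potency at all in this assay stays open.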